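The source may report more compounds than this note shows. Statements on the series, on what has been measured and on what is new or still open speak of the compounds shown alone.

Compound 3 `CS/C(=N\C(=O)c1cccs1)NC(=O)c1cccs1` and compound 2 `O=C(/N=C(/NC(=O)c1cccs1)[Se]Cc1ccccc1)c1cccs1` share one core, while compound 1 `CS/C(=N\C(=O)c1ccco1)NC(=O)c1ccco1` carries a second core; the difference between the two cores is not broken down here. In a functional assay on HT-29 cells (Homo sapiens) for cytotoxicity, read by MTT assay, with a stated time of 72 h (a higher number here means that more compound is tolerated, a lower number that less compound is tolerated), compound 3 gives > 100000 nM, which is a limit of the assay and not a number. Compound 2 gives > 100000 nM in this assay, again a limit. Compound 1 gives > 100000 nM in this assay, also a limit. The change from compound 3 to compound 2 is a group of 8 heavy atoms (7 carbon, 1 selenium; one six-membered aromatic ring of carbon only) in place of a group of 2 heavy atoms (1 carbon, 1 sulfur; no ring), on a carbon with a double bond to nitrogen, and it gives a step that the two limits leave unreadable from compound 3 to compound 2; this step cannot be sized because of the limit of > 100000 nM in this assay, at which 3 of the 3 values shown sit. Compound 4 `O=C(/N=C(/NC(=O)c1ccco1)[Se]Cc1ccccc1)c1ccco1` is not yet measured and differs from compound 1 by a group of 8 heavy atoms (7 carbon, 1 selenium; one six-membered aromatic ring of carbon only) in place of a group of 2 heavy atoms (1 carbon, 1 sulfur; no ring), on a carbon with a double bond to nitrogen, the same change at a place described in the same words. The step from compound 1 to compound 4 is expected to be a number no higher from compound 1 to compound 4 (the limit leaves the size open), set beside the earlier step, because the limit of > 100000 nM in this assay, at which 3 of the 3 values shown sit, gives no readable size for this change. Compound 4 is therefore estimated at 100000 nM in this assay, most likely reported once more as a limit rather than a number.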

Compound 4, concentration lethal to 50% of the cells: 89100 nM
Estimate against measurement, compound 4: 1.1-fold (0.05 log units) above; the measured number falls inside the stated range.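

In this assay, putting the selenium-bearing group in place of methylsulfanyl on the core of compound 1 gives an at least 1.1-fold lower number from compound 1 to compound 4 (0.05 log units; that floor lies within the scatter), a step with only one readable end, since the value of compound 1 is a limit and not a number. The true step could be larger, but what can be read of it does not go beyond the usual scatter, so this does not show that the change lowers the number. Nor does it show whether the change acts alike on both cores, since the same change on the core of compound 3 cannot be read and the two steps cannot be compared, because of this: the limit of > 100000 nM in this assay, at which 3 of the 4 values shown sit.

It remains open whether the selenium or the six-membered aromatic ring of the entering group matters more, since no benzylsulfanyl group appears on that carbon among the compounds shown. On these data alone, how an amine or a longer chain at that place would read in this assay also remains open.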